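The source may report more compounds than this note shows. Statements on the series, on what has been measured and on what is new or still open speak of the compounds shown alone.

Compound 2 `Cc1cc(C)n2ncc(Cl)c2n1` gives 10 mg/kg in a functional assay on the whole organism with Rattus norvegicus as the target (on this read-out higher numbers stand for an effect only at larger amounts of compound and lower numbers for an effect already at smaller amounts), level with compound 3 `Cc1cc(C)n2ncc(Br)c2n1`, which gives 10 mg/kg, and together these are the lowest of the three numbers; the unsubstituted parent compound 1 `Cc1cc(C)n2nccc2n1` gives 40 mg/kg. Compound 4 `Cc1cc(C)n2ncc(I)c2n1` differs from compound 2 by iodo in place of chloro on an aromatic carbon. The step that bears most directly on this change is the halogen exchange no change at the digits printed from compound 2 to compound 3 (within the scatter), while both a 4.0-fold lower number from compound 1 to compound 2 (0.60 log units; beyond the scatter) and a 4.0-fold lower number from compound 1 to compound 3 (0.60 log units; beyond the scatter) show that either halogen at this carbon lowers the dose by the same amount. Since swapping one halogen for another left the number unchanged, the step of no change at the digits printed from compound 2 to compound 4 (within the scatter) is expected to stay within the scatter. Compound 4 is therefore estimated at 10 mg/kg, with a likely range from 4 mg/kg to 25 mg/kg.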

Compound 4, minimum effective dose: 20 mg/kg
The estimate for compound 4 lay 2.0-fold (0.30 log units) below the measured number, and the stated range covers the measured number.
By their numbers in this assay, from the lowest: compounds 2, 3, 4 and 1 (each within the scatter of the next, the first and the last beyond it).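

On this assay iodo on this aromatic carbon stays within the scatter of both chloro (a 2.0-fold higher number from compound 2 to compound 4 (0.30 log units; within the scatter)) and bromo (a 2.0-fold higher number from compound 3 to compound 4 (0.30 log units; within the scatter)). It also stays within the scatter of hydrogen (a 2.0-fold lower number from compound 1 to compound 4 (0.30 log units; within the scatter)), so unlike chloro and bromo, iodo is not separated from the parent. The halogens at this carbon therefore do not all stand clear of hydrogen, although the three halogen compounds cannot be told apart from one another. Nothing available explains this result. Still open, going by these compounds, is whether fluoro, a methoxy group or an amine on this carbon would stand clear of hydrogen, as chloro and bromo do.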